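Benzoxazole-free notes: chloro to methoxy on the fused ring

This account rests on a few compounds, and the source may have more. Where it says the series, first, only, none or still open, it means among the compounds named here.

Measured compounds:
compound 1 `CCc1ccc(Nc2nc3ccccc3o2)cc1` gives 1210 nM
compound 2 `Clc1ccc2oc(Nc3ccccc3)nc2c1` gives 4500 nM
compound 3 `COc1cccc(Nc2nc3cc(C)ccc3o2)c1` gives 6830 nM

In an assay on isolated protein (strain Balb/c) for inhibition of Polyunsaturated fatty acid 5-lipoxygenase (Mus musculus), read by immunoassay, with a stated time of 20 min (a lower number here means a stronger inhibitor, a higher number a weaker inhibitor), compound 2 stands second highest of the three numbers. Its nearest neighbour is compound 3, whose value lies within the scatter of it, so no order between the two can be claimed. The furthest is compound 1, whose number is lower by a margin beyond the scatter, so compound 1 is the stronger inhibitor of that pair.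

The unmeasured compound 4 `COc1ccc2oc(Nc3ccccc3)nc2c1` differs from compound 2 in one place: methoxy in place of chloro on an aromatic carbon. Within the data shown here, no step between two measured compounds isolates this change. Compound 3 also carries a methoxy, though on the other ring, and a methyl on the fused ring, and sits within the scatter of compound 2; compound 1 carries no substituent on the fused ring at all and gives the lowest number. These three values give no consistent direction for a change on the fused ring, so the expectation for compound 4 is a step of no more than the scatter, leaning if anything toward a somewhat higher number.

On that basis compound 4 is estimated at 5500 nM, in the range 1800 nM to 16000 nM. The expected step from compound 2 to compound 4 is a 1.2-fold higher number from compound 2 to compound 4 (0.09 log units; within the scatter), within the scatter, and is to be confirmed by measurement.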

Compound 4, half-maximal inhibitory concentration: 7880 nM
Compound 4: the middle estimate sits 1.4-fold (0.16 log units) below what was measured; the range from low to high includes it.
By their numbers in this assay, from the lowest: compound 1; then compounds 2, 3 and 4 (each within the scatter of the next).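

In this assay, among these compounds, methoxy in place of chloro on this aromatic carbon gives a 1.8-fold higher number from compound 2 to compound 4 (0.24 log units; within the scatter), and this is the first step that isolates a single change at one place. At this position, then, the two groups cannot be told apart in this read-out, although the counts differ: methoxy has more heavy atoms than chloro and carries a hydrogen-bond acceptor, which chloro does not. Nothing available bears on why the exchange leaves the number within the scatter.

The compounds shown leave open whether any group on this carbon can move the number beyond the scatter, since only chloro and methoxy can be compared here, and an amine, a carboxylic acid or a longer chain such as ethoxy would extend that comparison. Also open, as far as these compounds go, is whether the exchange of chloro for methoxy would read the same with a substituent on the other ring of the shared core.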